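The compounds below may be only part of what the source reports. "The series", "measured", "known", "first", "only" and "open" are said of these compounds alone.

Measured so far in a functional assay on HeLa cells (Homo sapiens) for antiproliferative activity, read by WST assay, with a stated time of 24 h (on this read-out lower numbers stand for stronger inhibition and higher numbers for weaker inhibition), for this series:

Compound 1 `C=C[C@]1(C)CC[C@@H](C(=C)COCCOC)C[C@H]1C(=C)C` gives 238000 nM
Compound 2 `C=C[C@]1(C)CC[C@@H](C(=C)CNC2CCCCCCC2)C[C@H]1C(=C)C` gives 5900 nM
Compound 3 `C=C[C@]1(C)CC[C@@H](C(=C)CNC(C)C)C[C@H]1C(=C)C` gives 40 nM

Of these three, compound 3 at 40 nM has the lowest number. Compound 4 `C=C[C@]1(C)CC[C@@H](C(=C)CNC2CCCCC2)C[C@H]1C(=C)C` has not yet been measured. The change cyclohexyl in place of isopropyl on an amine nitrogen puts cyclohexyl in place of isopropyl on an amine nitrogen. The closest evidence is a 150-fold lower number from compound 2 to compound 3 (2.17 log units; beyond the scatter) which is large and also exchanges a carbon ring and isopropyl on that nitrogen. The other step, a 6000-fold lower number from compound 1 to compound 3 (3.77 log units; beyond the scatter) is also large but replaces a different kind of group, so it bears less directly. A large rise in this assay is therefore expected, though a smaller one than the step involving cyclooctyl. The estimated step is a 13-fold higher number from compound 3 to compound 4 (1.10 log units; beyond the scatter) upward. For compound 4 the estimated value is 500 nM with 60 nM to 5000 nM as the expected range.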

Compound 4, half-maximal inhibitory concentration: 3390 nM
Compound 4: middle estimate off by 6.8-fold (0.83 log units), on the low side, and the stated range covers the measured number.
By their numbers in this assay, from the lowest: compound 3; then compounds 4 and 2 (each within the scatter of the next); then compound 1.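

In this assay, the rise on leaving isopropyl does not need a ring as large as cyclooctyl: an 85-fold higher number from compound 3 to compound 4 (1.93 log units; beyond the scatter) is already large, while a 1.7-fold lower number from compound 2 to compound 4 (0.24 log units; within the scatter) lies within the scatter, so cyclohexyl and cyclooctyl on this amine nitrogen cannot be told apart. The cyclohexylamino group still keeps a large advantage over 2-methoxyethoxy, with a 70-fold lower number from compound 1 to compound 4 (1.85 log units; beyond the scatter). Nothing at hand explains these differences.

The compounds shown leave open whether a cyclopropyl or cyclobutyl ring on this nitrogen stays close to compound 3 or to compound 4. They also leave open how an open chain such as tert-butyl or n-hexyl would compare.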